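The compounds below may be only part of what the source reports. "The series", "measured", "known", "first", "only" and "open" are said of these compounds alone.

Compounds 1 and 2 share one core and differ only in the substituted phenyl group on the amide carbonyl. In a functional assay on MCF7 cells (Homo sapiens) for inhibition, read by MTT assay (a higher number here means a weaker inhibitor, a lower number a stronger inhibitor), compound 1 (`COc1cc2ncnc(Nc3ccc(NC(=O)c4ccc(Cl)cc4)cc3)c2cc1OC`) gives 30000 nM and compound 2 (`COc1cc2ncnc(Nc3ccc(NC(=O)c4cccc(I)c4)cc3)c2cc1OC`) gives 30000 nM on the same scale. Compound 2 therefore stands level with compound 1, and both sit at a high number, which marks weak inhibition.

The next structure, compound 3 (`COc1cc2ncnc(Nc3ccc(NC(=O)c4c(F)cccc4F)cc3)c2cc1OC`), keeps the core and the amide but changes the group on the carbonyl: 2,6-difluorophenyl in place of 3-iodophenyl on a carbonyl carbon. In words, this puts 2,6-difluorophenyl in place of 3-iodophenyl on a carbonyl carbon.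

Among the compounds with values here, only one measured step bears on this swap. It also exchanged one substituted phenyl for another on that carbonyl carbon, and it reads no change at the digits printed from compound 1 to compound 2 (within the scatter) with no shift to report. Within the data shown here, this is thin evidence, since no measured compound carries the 2,6-difluorophenyl group. Even so, the one precedent points to little movement. In this assay the expected change is no change at the digits printed from compound 2 to compound 3 (within the scatter) and nothing beyond the scatter is anticipated. The estimated value for compound 3 is 30000 nM with an expected range from 12000 nM to 60000 nM for this measurement.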

Compound 3, half-maximal inhibitory concentration: 24000 nM
For compound 3 the middle estimate is 1.3-fold (0.10 log units) above the measured one, within the range that was stated.
By their numbers in this assay, from the lowest: compounds 3, 1 and 2 (each within the scatter of the next).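

In this assay, compounds 1 and 2 showed only a swap of one halogen-bearing phenyl for another on this carbonyl carbon, and the 2,6-difluorophenyl group now extends that comparison to a ring with two fluorines, giving a 1.3-fold lower number from compound 2 to compound 3 (0.10 log units; within the scatter). Set against the 4-chlorophenyl group, the reading is a 1.3-fold lower number from compound 1 to compound 3 (0.10 log units; within the scatter), so all three substituted phenyl groups on this carbonyl carbon lie within the scatter of each other, at high numbers that mark weak inhibition. For these compounds, then, changing which halogens the phenyl ring carries does not separate them in this cell assay, and nothing measured here offers an explanation for that flat result.

On these data alone, every group on this carbonyl carbon so far is a halogen-bearing phenyl, so it remains open whether a phenyl carrying an amine or a carboxylic acid, or a cyclohexyl ring or a longer alkyl chain in place of the phenyl, would read any differently. All three compounds also keep the same core and amide, which leaves the effect of changes at those parts of the structure unknown.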